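Amide variation at the carbonyl carbon: compound 4 expected

The source may hold more compounds than are shown below. What is called first, only, known or untested is meant among the compounds shown, and "the series" means these compounds.

Compound 1 `CCN(CC)S(=O)(=O)c1ccc(S(=O)(=O)N2CCC[C@@H](C(=O)N3CCOCC3)C2)cc1`, compound 2 `CN(C)S(=O)(=O)c1ccc(S(=O)(=O)N2CCC[C@@H](C(=O)N3CCC(F)(F)CC3)C2)cc1` and compound 3 `CCN(CC)S(=O)(=O)c1ccc(S(=O)(=O)N2CCC[C@@H](C(=O)N3CCC(COC)CC3)C2)cc1` share one core and differ only in the ring attached at the carbonyl carbon. In a functional assay on MIA PaCa-2 cells (Homo sapiens) for inhibition, read by MTT assay, with a stated time of 3 days (on this read-out higher numbers stand for weaker inhibition and lower numbers for stronger inhibition), compound 1 gives only a limit, > 10000 nM. Compound 2 likewise gives only a limit in this assay, > 3000 nM. Compound 3 also stands at a limit in this assay, > 10000 nM. The step that the two limits leave unreadable from compound 1 to compound 3 is thus unreadable, since every value shown is a limit (the limit of > 10000 nM in this assay, at which 2 of the 3 values shown sit; (the limit of > 3000 nM in this assay, at which 1 of the 3 values shown sits)). Compound 4 `CCN(CC)S(=O)(=O)c1ccc(S(=O)(=O)N2CCC[C@@H](C(=O)N3CC[C@H](OC)C3)C2)cc1` differs from compound 3 in one place: 3-methoxypyrrolidin-1-yl in place of 4-(methoxymethyl)piperidin-1-yl on a carbonyl carbon. Within the data shown here, no measured step bears readably on this change. Compound 4 is therefore expected to sit at a limit again, the estimated step that the limit leaves unreadable from compound 3 to compound 4 being unresolvable. The estimate for compound 4 in this assay is 15000 nM, ranging from 4000 nM to 60000 nM.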

Compound 4, half-maximal inhibitory concentration: > 10000 nM
Compound 4 ended at the assay's limit; the forecaster's own chance of this, stated with the estimate: 80%; the middle value is on the limit's open side.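

Compound 1, compound 3 and compound 4 stand only at a limit, so no step among them can be read: the limit of > 10000 nM in this assay, at which 3 of the 4 values shown sit.

The compounds shown leave open whether any group on the carbonyl carbon gives a value inside the readable range of this assay.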